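This account rests on a few compounds, and the source may have more. Where it says the series, first, only, none or still open, it means among the compounds named here.

Of the compounds shown here, three have so far been measured in a functional assay on A549 cells (Homo sapiens) for antiproliferative activity, read by CCK-8 assay, with a stated time of 72 h; on this read-out lower numbers stand for stronger inhibition and higher numbers for weaker inhibition. Compound 1 `O=C(/C=C/c1ccc(CN2CCc3ccccc32)cc1)NO` gives 5480 nM. Compound 2 `Nc1cc(F)ccc1NC(=O)c1ccc(COc2ccccc2)cc1` gives 8340 nM. Compound 3 `Nc1ccccc1NC(=O)c1ccc(COc2ccc(F)cc2)cc1` gives 5370 nM, the lowest of the three numbers, although its gap to compound 1 and its gap to compound 2 both lie within the usual scatter of repeated measurements, so none of the three can be set apart from the others on these figures.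

Compound 4 `CCc1ccc(OCc2ccc(C(=O)Nc3ccccc3N)cc2)cc1` keeps the shared core of compound 3 and differs from it in a single place: ethyl in place of fluoro on an aromatic carbon. Put another way, the 4-fluorophenyl of compound 3 becomes 4-ethylphenyl in compound 4. For the measured compounds named here, no measured pair shows this particular change, so its effect cannot be read off directly. Ethyl in place of fluoro on an aromatic carbon is a small alteration, and nothing among the measured compounds points to a large shift in either direction. The step of a 1.1-fold lower number from compound 3 to compound 4 (0.03 log units; within the scatter) is therefore expected to stay close to zero, within the scatter. Compound 4 is estimated at 5000 nM, with a range from 2000 nM to 13000 nM, because compound 3 gives 5370 nM and the change is minor.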

Compound 4, half-maximal inhibitory concentration: 6420 nM
For compound 4 the middle estimate is 1.3-fold (0.11 log units) below the measured one; measured number inside the range.
By their numbers in this assay, from the lowest: compounds 3, 1, 4 and 2 (each within the scatter of the next).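

In this assay, for the compounds shown here, the swap of fluoro for ethyl, on an aromatic carbon para to a large group, comes with a 1.2-fold higher number from compound 3 to compound 4 (0.08 log units; within the scatter) and gives the first direct reading of a single change. The 4-fluorophenyl and 4-ethylphenyl compounds cannot be told apart on these figures, even though the entering group holds two heavy atoms where the leaving group holds one, so this position accepts at least this one change without a step beyond the scatter. No measurement available here accounts for the result.

Going by these compounds, what an amine, a carboxylic acid or a longer chain such as hexyl would give at this position remains open, and one pair cannot show how far the tolerance seen here extends. On these data alone, it is also open whether ethyl in place of fluoro would read the same way on a different core, such as that of compound 2.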